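Benzylsulfanyl variation on a shared core

The compounds below may be only part of what the source reports. "The series", "measured", "known", "first", "only" and "open" are said of these compounds alone.

Measured so far:
compound 1 `O=C(O)c1ccc(C(=O)/C(=C\c2ccc(Cl)c([N+](=O)[O-])c2)SCc2ccc(C(F)(F)F)cc2)cc1`: 1000 nM
compound 2 `O=C(O)c1ccc(C(=O)/C(=C\c2ccc(Cl)c([N+](=O)[O-])c2)SCc2ccc(Cl)cc2)cc1`: 1000 nM
compound 3 `O=C(O)c1ccc(C(=O)/C(=C\c2ccc(Cl)c([N+](=O)[O-])c2)SCc2ccc(Br)cc2)cc1`: 500 nM

All three were run in a functional assay on DU-145 cells (Homo sapiens) for inhibition, read by trypan blue exclusion, with a stated time of 96 h; on this read-out higher numbers stand for weaker inhibition of growth and lower numbers for stronger inhibition of growth. Compound 3 gives the lowest of the three numbers, but the steps to it are within the scatter: a 2.0-fold lower number from compound 1 to compound 3 (0.30 log units; within the scatter) and a 2.0-fold lower number from compound 2 to compound 3 (0.30 log units; within the scatter), and likewise no change at the digits printed from compound 1 to compound 2 (within the scatter). So the three substituents on that ring are not distinguished by these data.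

Compound 4 `O=C(O)c1ccc(C(=O)/C(=C\c2ccc(Cl)c([N+](=O)[O-])c2)SCc2ccc(Cl)cc2Cl)cc1` differs from compound 3 by 2,4-dichlorophenyl in place of 4-bromophenyl on a saturated chain carbon bound to a sulfur. Among the compounds with values here, the steps that bear on it are the three above, all exchanges on the same ring, none beyond the scatter. A step of about that size is therefore expected, a 1.4-fold higher number from compound 3 to compound 4 (0.15 log units; within the scatter), with no firm direction. Compound 4 is estimated at 700 nM, between 300 nM and 2000 nM.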

Compound 4, concentration for 50% growth inhibition: 1000 nM
Compound 4: the middle estimate sits 1.4-fold (0.15 log units) below what was measured; the measured number falls inside the stated range.
By their numbers in this assay, from the lowest: compounds 3, 1, 2 and 4 (each within the scatter of the next).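

In this assay adding a chloro group to the aromatic ring gives no change at the digits printed from compound 2 to compound 4 (within the scatter) so this first added ring substituent in the series is not separated from hydrogen. The exchanges to 2,4-dichlorophenyl give a 2.0-fold higher number from compound 3 to compound 4 (0.30 log units; within the scatter) and no change at the digits printed from compound 1 to compound 4 (within the scatter) so the four aryl groups on the saturated chain carbon bound to a sulfur remain undistinguished by these data. On these data alone, whether an amine or a carboxylic acid on that ring, or a longer chain bound to the sulfur, would move the number beyond the scatter stays open. No measurement at hand speaks to the reason for these results.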